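Swapping the fluorophenyl for dimethylisoxazole on a sulfone acid

This account rests on a few compounds, and the source may have more. Where it says the series, first, only, none or still open, it means among the compounds named here.

Measured so far:
Compound 1 `COc1cc(C)c(-c2cccc(COc3ccc4c(c3)SCC4CC(=O)O)c2)c(C)c1` gives 123 nM in a functional assay on CHO cells for agonist activity at Free fatty acid receptor 1 (Homo sapiens), read by FLIPR and calcium flux; on this read-out higher numbers stand for an effect only at larger amounts of compound and lower numbers for an effect already at smaller amounts.
Compound 2 `O=C(O)CS(=O)(=O)c1ccc(OCc2cccc(-c3ccccc3F)c2)cc1` gives 257 nM in this assay.

Compound 2 stands at the higher of the two numbers; compound 1 sits at the lower one, and that gap lies beyond the scatter. Compound 3 `Cc1noc(C)c1-c1cccc(COc2ccc(S(=O)(=O)CC(=O)O)cc2)c1` differs from compound 2 as follows: 3,5-dimethyl-1,2-oxazol-4-yl in place of 2-fluorophenyl on an aromatic carbon. Going by the values given here, no measured pair shows this change, so the step is uncertain; a modest step toward a higher number is expected, possibly no larger than the scatter, and the estimated step is a 1.6-fold higher number from compound 2 to compound 3 (0.19 log units; within the scatter). Compound 3 is thus expected to give about 400 nM, within a range from 150 nM to 1200 nM.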

Compound 3, half-maximal effective concentration: 269 nM
Compound 3: middle estimate off by 1.5-fold (0.17 log units), on the high side; low and high end bracket the measured number.
By their numbers in this assay, from the lowest: compound 1; then compounds 2 and 3 (each within the scatter of the next).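

In this assay, this position on the aromatic carbon accepts a five-membered aromatic ring with 2 hetero atoms as readily as a six-membered ring of carbon only: 3,5-dimethyl-1,2-oxazol-4-yl in place of 2-fluorophenyl gives a 1.0-fold higher number from compound 2 to compound 3 (0.02 log units; within the scatter) and so cannot be told apart from it here. The entering group brings 2 hydrogen-bond acceptors and the leaving group none, yet the read-out does not separate them. Nothing available bears on why the two groups read alike. On these data alone, it remains open whether an amine or a plain methyl at this position would keep the number, and whether the same exchange would hold on the core of compound 1.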